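Compound 1 to compound 4: butyl to thiophen-2-yl

This account rests on a few compounds, and the source may have more. Where it says the series, first, only, none or still open, it means among the compounds named here.

In a functional assay on HeLa cells (Homo sapiens) for cytotoxicity (on this read-out higher numbers stand for weaker inhibition and lower numbers for stronger inhibition), compound 1 (`CCCCOC1=CC(=O)c2ccccc2C1=O`) gives 35300 nM as its reading. Compound 2 (`CS(=O)(=O)Oc1ccc2c(c1)C(=O)C=CC2=O`) gives 17700 nM and sits within the scatter of compound 1. Compound 3 (`O=C1C=CC(=O)c2cc(Oc3ccco3)ccc21`) gives 17200 nM and so falls on the lower side of compound 1, only just beyond the scatter.

Compound 4 (`O=C1C=C(Oc2cccs2)C(=O)c2ccccc21`) has not been measured. It differs from compound 1 by thiophen-2-yl in place of butyl on an oxygen on an unsaturated carbon.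

Among the measured compounds shown here, one measured step bears on this, and only indirectly. The step of a 1.0-fold lower number from compound 2 to compound 3 (0.01 log units; within the scatter) puts furan-2-yl in place of methylsulfonyl on an oxygen on an aromatic ring, and it stays within the scatter. For the measured compounds named here, no measured step replaces butyl, and none changes the group at the place in question. Compound 1 and compound 3 differ in more than one place, so their gap is a weak guide.

A small shift toward a lower number is expected, since compound 3 at 17200 nM also carries a five-membered aromatic ring on its oxygen. In this assay the estimated move is a 1.8-fold lower number from compound 1 to compound 4 (0.25 log units; within the scatter) and nothing clearly beyond the scatter is expected. For compound 4 the expected value is 20000 nM with an estimated range from 8000 nM to 45000 nM for now.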

Compound 4, half-maximal inhibitory concentration: 35300 nM
Beside the measured number, compound 4's estimate is 1.8-fold (0.25 log units) below it; measured number inside the range.
By their numbers in this assay, from the lowest: compounds 3, 2, 1 and 4 (each within the scatter of the next, the first and the last beyond it).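

In this assay the oxygen on an unsaturated carbon now has its first measured change, and thiophen-2-yl in place of butyl gives no change at the digits printed from compound 1 to compound 4 (within the scatter) for this pair. Among the compounds shown here, at this place, an open butyl chain and a five-membered aromatic ring with one hetero atom therefore cannot be told apart by this read-out, which the earlier compounds could not show because none of their steps touched this group. Nothing measured here accounts for the match, so it stands as an observation without an explanation.

On these data alone, only these two groups have been compared on this oxygen, so it remains open whether the flat reading extends to others, such as a longer alkyl chain, a phenyl ring, a chain ending in an amine or one ending in a carboxylic acid. Also open, as far as these compounds go, is whether the same exchange of butyl for thiophen-2-yl would read alike on a different core, as a single pair says nothing about that.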